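Cytotoxicity on a Shared Core: From Compound 2 to Compound 4

The compounds below may be only part of what the source reports. "The series", "measured", "known", "first", "only" and "open" are said of these compounds alone.

Compound 1 `O=c1cc(NCc2ccc3c(c2)OCCO3)sc2c([N+](=O)[O-])cc(C(F)(F)F)cc12`: > 64 ug/mL
Compound 2 `O=c1cc(NCc2cccc(F)c2)sc2c([N+](=O)[O-])cc(C(F)(F)F)cc12`: > 64 ug/mL
Compound 3 `O=c1cc(Nc2ccccc2)sc2c([N+](=O)[O-])cc(C(F)(F)F)cc12`: > 64 ug/mL

Of the compounds shown here, three on a shared core have been tested in an ADME assay on Vero cells (Chlorocebus sabaeus) for cytotoxicity, read by MTT assay, with a stated time of 48 h; a higher number here means a weaker inhibitor, a lower number a stronger inhibitor. In this assay compound 1 gives > 64 ug/mL, which is a limit of the assay and not a number. Compound 2 gives > 64 ug/mL in this assay, again a limit. Compound 3 gives > 64 ug/mL in this assay, also a limit. Compound 2 thus stands at the same limit as the other two, and (the limit of > 64 ug/mL in this assay, at which 3 of the 3 values shown sit). The step that the two limits leave unreadable from compound 1 to compound 2 and the step that the two limits leave unreadable from compound 2 to compound 3 therefore cannot be sized; both ends of each sit at the limit.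

Compound 4 `COc1ccc(CNc2cc(=O)c3cc(C(F)(F)F)cc([N+](=O)[O-])c3s2)cc1OC` differs from compound 2 by 3,4-dimethoxyphenyl in place of 3-fluorophenyl on a saturated chain carbon bound to a nitrogen on an aromatic ring. The two measured steps bear on this change only in that they alter the same group on the saturated chain carbon bound to the nitrogen, and neither gave a readable size. With every measured value at the limit, no step beyond the scatter can be read from compound 2 to compound 4, and the expectation is that compound 4 also sits at the limit. Compound 4 is estimated to give 80 ug/mL, within a range from 45 ug/mL to 150 ug/mL. The step that the limit leaves unreadable from compound 2 to compound 4 is expected to be none beyond the scatter.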

Compound 4, half-maximal inhibitory concentration: > 64 ug/mL
Compound 4 gave a limit, no number; the forecaster's own chance of this, stated with the estimate: 80%; the middle value lies beyond the limit too.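

In this assay compound 4 gives > 64 ug/mL, which is a limit and not a number. No step from compound 1 or compound 2 to compound 4 can be read, since the values stand at one limit: the limit of > 64 ug/mL in this assay, at which 4 of the 4 values shown sit.

The compounds shown leave open whether the groups on the saturated chain carbon differ in cytotoxicity at all, and where each compound's true value lies.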